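A cyclopentyl swap on compound 1

A few compounds are considered here, and "the series" means these few. Any claim that something is new, unique, unknown or untested is made for them only; others in the source may bear on it.

Measured in an in vivo functional assay on the whole organism (MDA-MB-435 cells, Homo sapiens) for antiproliferative activity; a higher number here means a weaker inhibitor, a lower number a stronger inhibitor:
- compound 1 `CO[C@@H](C(=O)NC1CC[C@@H](OC(=O)CC2CCCCC2)CNC1=O)[C@H](O)[C@@H](O)[C@H](O)/C=C/C(C)(C)C`: 60 nM
- compound 2 `CCCCCCCCCCCCCC(=O)O[C@@H]1CCC(NC(=O)[C@H](OC)[C@H](O)[C@@H](O)[C@H](O)/C=C/C(C)(C)C)C(=O)NC1`: < 10 nM (a limit of the assay, not a number)
- compound 3 `CCCCCCCCCCc1ccc(C(=O)O[C@@H]2CCC(NC(=O)[C@H](OC)[C@H](O)[C@@H](O)[C@H](O)/C=C/C(C)(C)C)C(=O)NC2)cc1`: 30 nM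

Compound 1 gives 60 nM and compound 3 gives 30 nM, two values within the scatter of each other. Compound 2 is reported only as a limit, < 10 nM.

Compound 4 `CO[C@@H](C(=O)NC1CC[C@@H](OC(=O)C2CCCC2)CNC1=O)[C@H](O)[C@@H](O)[C@H](O)/C=C/C(C)(C)C` differs from compound 1 in one place: cyclopentyl in place of cyclohexylmethyl on a carbonyl carbon. In words, this is cyclopentyl in place of cyclohexylmethyl on a carbonyl carbon.

Within the data shown here, one measured step bears on this change: an at least 6.0-fold lower number from compound 1 to compound 2 (0.77 log units; beyond the scatter). There, dodecyl took the place of cyclohexyl on a saturated chain carbon bound to a carbonyl carbon. Going by these compounds, that step lies beyond the scatter, but it ends at a limit and its full size is unknown. It also enlarged the group, whereas the group entering compound 4 is the smaller one, so it offers only a weak guide to direction. Among the measured compounds shown here, no measured step shows a swap between two rings.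

Starting from compound 1 at 60 nM, a change no larger than the scatter is expected in this assay, leaning if anything towards a higher number. The estimated change is a 1.7-fold higher number from compound 1 to compound 4 (0.22 log units; within the scatter). For compound 4 the expected value is 100 nM, with an estimated range of 30 nM to 350 nM.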

Compound 4, half-maximal inhibitory concentration: 130 nM
For compound 4 the middle estimate is 1.3-fold (0.11 log units) below the measured one, within the range that was stated.
By their numbers in this assay, from the lowest: compounds 3 and 1 (each within the scatter of the next); then compound 4. At a limit, below all of these: compound 2.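

In this assay, among these compounds, cyclopentyl in place of cyclohexylmethyl on a carbonyl carbon gives a 2.2-fold higher number from compound 1 to compound 4 (0.34 log units; beyond the scatter), and this is the first step at this position with a measured number at both ends. Among the compounds shown here, it is also the first step to a smaller group here, and it shows that this position registers even a change between two rings of carbon only, neither with any hydrogen-bond donors or acceptors. The earlier step to the dodecyl ester of compound 2 still cannot be sized against it, so the two steps give direction only and no common scale: the limit of < 10 nM in this assay, at which 1 of the 4 values shown sits.

The new step shortens the group and changes the ring from six-membered to five-membered at once, so the compounds shown cannot separate these two changes, and a cyclopentylmethyl or cyclohexyl group on the same carbonyl carbon would be needed to do so. They also leave open how this position would respond to a group that carries an amine or a carboxylic acid, since every group compared here is made of carbon only.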